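This account rests on a few compounds, and the source may have more. Where it says the series, first, only, none or still open, it means among the compounds named here.

Notes on the series in an ADME assay on L6 cells (Rattus norvegicus) for cytotoxicity, read by resazurin assay, with a stated time of 70 h; on this read-out higher numbers stand for weaker inhibition and lower numbers for stronger inhibition. Compound 1 `CC1=CC(C)(C)N(Cc2ccc(C)cc2)c2ccc(O)cc21` gives 8100 nM in this assay. For the measured compounds named here, compound 2 `CC(=O)Oc1ccc2c(c1)C(C)=CC(C)(C)N2Cc1ccc(C)cc1`, which carries an acetyl in place of hydrogen on an oxygen on an aromatic ring, gives 21000 nM in this assay; the step of a 2.6-fold higher number from compound 1 to compound 2 (0.41 log units; beyond the scatter) is the only measured step in the set. Going by the values given here, compound 2 therefore stands with the highest of the two numbers so far, compound 1 being its nearest neighbour.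

Compound 3 `CC(=O)Oc1ccc2c(c1)C(C)=CC(C)(C)N2Cc1ccc(F)cc1` has not yet been measured in this assay. It differs from compound 2 in one place: fluoro in place of methyl on an aromatic carbon. Among the compounds with values here, no measured step in the set bears on this change; the single step from compound 1 to compound 2 concerns a different place in the molecule and gives no guidance on a fluoro for methyl exchange on the benzyl ring. With nothing to lean on, compound 3 is expected to stay close to compound 2, with a step of no change at the digits printed from compound 2 to compound 3 (within the scatter) not expected to exceed the scatter. The estimate for compound 3 in this assay is 21000 nM, within a range from 9000 nM to 50000 nM.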

Compound 3, half-maximal inhibitory concentration: 29000 nM
The estimate for compound 3 lay 1.4-fold (0.14 log units) below the measured number, and the stated range covers the measured number.
By their numbers in this assay, from the lowest: compound 1; then compounds 2 and 3 (each within the scatter of the next).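

For the compounds shown here, exchanging 4-methylbenzyl for 4-fluorobenzyl with the acetyl kept in place gives a 1.4-fold higher number from compound 2 to compound 3 (0.14 log units; within the scatter) in this assay and so is the first measured step at this position, para to a large group, where methyl and fluoro cannot be told apart on this read-out. The step at the oxygen, a 2.6-fold higher number from compound 1 to compound 2 (0.41 log units; beyond the scatter), remains the only one in the series beyond the scatter, so of the two places varied only that one has so far separated compounds. No measurement at hand accounts for methyl and fluoro reading alike here.

On these data alone, only methyl and fluoro have been seen at this position, both with the acetyl on the oxygen, so it remains open whether a methoxy, an amine or a carboxylic acid there would move the number beyond the scatter. As far as these compounds go, it is also open whether the same fluoro for methyl exchange would read alike with the free hydroxyl of compound 1 in place of the acetyl.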